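The compounds below may be only part of what the source reports. "The series", "measured", "known", "first", "only" and "open" are said of these compounds alone.

Measured compounds:
- compound 1 `C=CCNC(=O)n1c(-c2ccc(OC)cc2)cc(=O)c2c(OC)cc(OC)cc21`, 12000 nM in a functional assay on SEM cells (Homo sapiens) for antiproliferative activity, with a stated time of 72 h; on this read-out lower numbers stand for an effect already at smaller amounts and higher numbers for an effect only at larger amounts of compound
- compound 2 `COc1ccc(-c2cc(=O)c3c(OC)cc(OC)cc3n2S(=O)(=O)c2cccc([N+](=O)[O-])c2)cc1`, "not determined" (no result reported) in this assay

Compound 1 carries an allylcarbamoyl group on the ring nitrogen of the shared core and gives 12000 nM in this assay. Compound 2 carries a sulfonyl group on the same nitrogen and stands at no single number: this assay was not determined for it, so its position on the scale is open.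

Compound 3 `COc1ccc(-c2cc(=O)c3c(OC)cc(OC)cc3n2S(=O)(=O)c2ccc(C#N)cc2)cc1` differs from compound 2 in one place: 4-cyanophenyl in place of 3-nitrophenyl on a sulfonyl sulfur. For the measured compounds named here, with compound 2 unmeasured, no step within this assay can be anchored between the two sulfonyl compounds, and neither a size nor a direction for the change is supported by data. Going by the values given here, the only measured reference is compound 1, a different substituent on the same nitrogen, at 12000 nM.

Compound 3 is expected to give about 6000 nM in this assay, with a range from 1000 nM to 30000 nM; this estimate rests on compound 1 at 12000 nM as the sole measured point of the series and is uncertain.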

Compound 3, half-maximal effective concentration: 1300 nM
For compound 3 the middle estimate is 4.6-fold (0.66 log units) above the measured one; the measured number falls inside the stated range.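

In this assay, for the compounds shown here, the aromatic nitrogen of the shared core carries a sulfonyl substituent with a measured result for the first time, and (4-cyanophenyl)sulfonyl in place of allylcarbamoyl gives a 9.2-fold lower number from compound 1 to compound 3 (0.97 log units; beyond the scatter). This shows that the substituent on this nitrogen affects the read-out by more than the usual scatter. The step between the 3-nitrophenyl and 4-cyanophenyl groups on the sulfonyl sulfur cannot be read, and no supporting evidence bears on why the number drops from the carbamoyl to the sulfonyl compound.

Still open, as far as these compounds go, is whether the lower number follows from the sulfonyl link or from the 4-cyanophenyl group. A benzoyl group on the same nitrogen, or a methylsulfonyl group in place of the arylsulfonyl group, would separate the two.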